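The source may hold more compounds than are shown below. What is called first, only, known or untested is meant among the compounds shown, and "the series" means these compounds.

Compound 1 `COc1cc(C(=O)c2cn(-c3ccc(Cl)cc3)cc2-c2ccccc2)cc(OC)c1OC` gives 140 nM.
Compound 2 `COc1cc(C(=O)c2cn(-c3ccc([N+](=O)[O-])cc3)cc2-c2ccccc2)cc(OC)c1OC` gives 4000 nM.
Compound 3 `COc1cc(C(=O)c2cn(-c3cccc(C)c3)cc2-c2ccccc2Cl)cc(OC)c1OC` gives 420 nM.

All three were measured in a functional assay on MCF7 cells (Homo sapiens) for cytotoxicity, read by MTT assay, with a stated time of 96 h; on this read-out lower numbers stand for stronger inhibition and higher numbers for weaker inhibition. Compound 1 and compound 2 share a core and differ in one place: nitro in place of chloro on an aromatic carbon. This change produced a 29-fold higher number from compound 1 to compound 2 (1.46 log units; beyond the scatter). Compound 3 carries a different core; the difference between the core of compound 1 and the core of compound 3 is not broken down here. In this assay compound 3 stands between the other two, with a gap beyond the scatter to compound 1 on one side and to compound 2 on the other.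

Compound 4 `COc1cc(C(=O)c2cn(-c3cccc(C)c3)cc2-c2ccccc2[N+](=O)[O-])cc(OC)c1OC` has not yet been measured. It is related to compound 3 in the way compound 2 is related to compound 1: nitro in place of chloro on an aromatic carbon. The two changes are of the same kind rather than the same: in compound 2 the entering group sits para to a large group, in compound 4 it sits ortho to a large group. The expectation for compound 4 rests on a single measured example of this kind of change, made on a different core, so it is read with caution. Because a 29-fold higher number from compound 1 to compound 2 (1.46 log units; beyond the scatter) moved the number far upward, compound 4 is expected to give a higher number than compound 3, with the step taken as somewhat smaller since the place of the change differs. The expected step is a 6.0-fold higher number from compound 3 to compound 4 (0.77 log units; beyond the scatter). Compound 4 is therefore estimated at 2500 nM, with a range from 800 nM to 8000 nM.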

Compound 4, half-maximal inhibitory concentration: 220 nM
The estimate for compound 4 lay 11-fold (1.06 log units) above the measured number, and the stated range ends above it.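

In this assay, nitro in place of chloro on an aromatic carbon, here 2-chlorophenyl to 2-nitrophenyl, gave a 1.9-fold lower number from compound 3 to compound 4 (0.28 log units; within the scatter), so the two values cannot be told apart on this read-out. Set beside the earlier step, the same change did not carry over from one core to the other, and its effect in this series therefore cannot be assumed from one core alone: the same change on two cores in this assay, a 29-fold higher number (1.46 log units; beyond the scatter) from compound 1 to compound 2 and a 1.9-fold lower number (0.28 log units; within the scatter) from compound 3 to compound 4, 55-fold (1.74 log units) apart, beyond the scatter of two such steps. This does not show why the steps differ, since the two cores and the two places of the change differ together and a single pair on each core cannot separate them, nor does it show how the change would behave on any further core.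

The compounds shown leave open whether the flat step seen at the 2-nitrophenyl group would hold for other groups at that place, such as an amine, a carboxylic acid or a nitrile. They also leave open what the same chloro to nitro change would do if it were made at one fixed place on both cores, which would test the place of the change apart from the core.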